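This account rests on a few compounds, and the source may have more. Where it says the series, first, only, none or still open, it means among the compounds named here.

For the measured compounds named here, of the two compounds measured so far in an assay on Prostate gland for inhibition of steroid 5-alpha-reductase (Rattus norvegicus) (on this read-out higher numbers stand for weaker inhibition and lower numbers for stronger inhibition), compound 2 `CCCCCC(CCCCC)n1ccc2cc(/C(C)=C/C(=O)Nc3ccccc3OCCCC(=O)O)ccc21` stands lowest: in this assay compound 2 gives 25 nM. Compound 1 `C/C(=C\C(=O)Nc1ccccc1OCCCC(=O)O)c1ccc2c(ccn2C)c1` shares the whole skeleton but carries only a methyl on the aromatic nitrogen of the fused ring system, and compound 1 gives 780 nM. Going by the values given here, the one step measured between them, a 31-fold lower number from compound 1 to compound 2 (1.49 log units; beyond the scatter), shows that the group on that nitrogen has a large effect on the read-out. Compound 3 `C/C(=C\C(=O)Nc1ccccc1OCCCC(=O)O)c1ccc2c(ccn2Cc2cccc(C)c2)c1` changes that same position again: 3-methylbenzyl in place of 1-pentylhexyl on an aromatic nitrogen. Among the compounds with values here, the only measured step that bears on this change is the one from the methyl to the 1-pentylhexyl group, and it was large. Within the data shown here, the 3-methylbenzyl group is neither as small as methyl nor as large as 1-pentylhexyl, and no measured compound tells how a ring on this nitrogen behaves. A number somewhere between those of compound 1 and compound 2 is therefore expected, closer to compound 2. The step this implies is estimated as a 3.6-fold higher number from compound 2 to compound 3 (0.56 log units; beyond the scatter). Compound 3 is expected to give 90 nM, with a likely range from 25 nM to 350 nM.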

Compound 3, half-maximal inhibitory concentration: 250 nM
The estimate for compound 3 lay 2.8-fold (0.44 log units) below the measured number, and the stated range covers the measured number.
By their numbers in this assay, from the lowest: compound 2; then compound 3; then compound 1.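

A ring-bearing group on this nitrogen now has a measured effect in this assay: adding a 3-methylphenyl to the methyl of compound 1 gives a clear gain, although a smaller one than the 1-pentylhexyl group gives (a 3.1-fold lower number from compound 1 to compound 3 (0.49 log units; beyond the scatter)). Replacing 1-pentylhexyl with 3-methylbenzyl loses much of that gain (a 10-fold higher number from compound 2 to compound 3 (1.00 log units; beyond the scatter)), so the three compounds fall in the order methyl, 3-methylbenzyl, 1-pentylhexyl, from the highest number to the lowest, and the ring-bearing group does not match the open-chain one with 11 heavy atoms. Nothing shown explains why these groups differ.

This last change swaps 11 heavy atoms for 8 and also brings in a ring, so the compounds shown cannot separate the effect of group size from that of the ring. A plain benzyl group would show what the methyl on the ring contributes, while an unbranched octyl chain or a cyclohexylmethyl group would help show whether the branching of 1-pentylhexyl or the aromatic character of the ring affects the number.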